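Bromo for chloro on the benzyl ring of compound 1

The source may report more compounds than this note shows. Statements on the series, on what has been measured and on what is new or still open speak of the compounds shown alone.

Compound 1 `CCCSc1nc(N/N=C(\C)c2ccccc2O)c2nnn(Cc3ccc(Cl)cc3)c2n1` — 42600 nM
Compound 2 `CCCSc1nc(N/N=C/c2cccnc2)c2nnn(Cc3ccccc3)c2n1` — 58700 nM
Compound 3 `CCCSc1nc(N/N=C/c2ccccc2)c2nnn(Cc3ccccc3)c2n1` — limit, > 64000 nM

In a functional assay on MCF7 cells (Homo sapiens) for antiproliferative activity, read by MTT assay, with a stated time of 72 h (on this read-out higher numbers stand for weaker inhibition and lower numbers for stronger inhibition), compound 1 gives 42600 nM, the lowest of the two numbers; compound 2 gives 58700 nM, within the scatter of it. For compound 3 the assay reports only a limit, > 64000 nM. Within the data shown here, the one measured step, an at least 1.0-fold higher number from compound 2 to compound 3 (0.03 log units; that floor lies within the scatter), concerns an aryl exchange on the hydrazone carbon, not the benzyl ring, so no measured step bears directly on the change to compound 4 `CCCSc1nc(N/N=C(\C)c2ccccc2O)c2nnn(Cc3ccc(Br)cc3)c2n1`: bromo in place of chloro on an aromatic carbon. Among the measured compounds shown here, with no relevant precedent, a step not beyond the scatter is expected, a 1.1-fold lower number from compound 1 to compound 4 (0.03 log units; within the scatter). Compound 4 is estimated at 40000 nM, within 18000 nM to 64000 nM.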

Compound 4, half-maximal inhibitory concentration: 15600 nM
The estimate for compound 4 lay 2.6-fold (0.41 log units) above the measured number, outside the stated range (below it).
By their numbers in this assay, from the lowest: compound 4; then compounds 1 and 2 (each within the scatter of the next). At a limit, above all of these: compound 3.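

In this assay, the benzyl ring of compound 1 proves responsive to a single halogen exchange: bromo in place of chloro gives a 2.7-fold lower number from compound 1 to compound 4 (0.44 log units; beyond the scatter) on the otherwise unchanged structure. Among these compounds, no earlier compound offered a step at this position, and here the change leaves ring count, hydrogen-bond donors and acceptors, and net charge as they were. No measurement shown bears on why the number moves.

On these data alone, whether iodo or methoxy at the same place would extend or reverse this step remains open. So does whether the exchange would act alike with the pyridin-3-yl hydrazone of compound 2.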